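The source may report more compounds than this note shows. Statements on the series, on what has been measured and on what is new or still open speak of the compounds shown alone.

Compound 2 `O=C(NC1CCCCC1)OC[C@H]1OC(n2cnc3c(NC4CCOC4)ncnc32)[C@H](O)[C@@H]1O` gives 584 nM in an assay on DDT1 cells (Cricetulus griseus) for binding affinity to adenosine receptor A1 (Homo sapiens), read by radioligand binding (on this read-out higher numbers stand for weaker inhibition and lower numbers for stronger inhibition), the highest of the two numbers measured. Compound 1 `CC/N=C(\S)OC[C@H]1OC(n2cnc3c(NC4CCOC4)ncnc32)[C@H](O)[C@@H]1O` gives 33 nM in this assay, so that an 18-fold higher number from compound 1 to compound 2 (1.25 log units; beyond the scatter). Compound 3 `C=CC/N=C(\S)OC[C@H]1OC(n2cnc3c(NC4CCOC4)ncnc32)[C@H](O)[C@@H]1O` differs from compound 2 by a group of 6 heavy atoms (4 carbon, 1 nitrogen, 1 sulfur; no ring) in place of a group of 9 heavy atoms (7 carbon, 1 nitrogen, 1 oxygen; one six-membered non-aromatic ring of carbon only), on an oxygen on a saturated carbon, a change that brings the structure back close to that of compound 1. Going by the values given here, only the step of an 18-fold higher number from compound 1 to compound 2 (1.25 log units; beyond the scatter) bears on it, and it was large; a step of similar size in the opposite direction is therefore expected, a 15-fold lower number from compound 2 to compound 3 (1.16 log units; beyond the scatter). Compound 3 is thus estimated at 40 nM in this assay, with a range from 15 nM to 120 nM.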

Compound 3, inhibition constant: 35 nM
Beside the measured number, compound 3's estimate is 1.1-fold (0.06 log units) above it; low and high end bracket the measured number.
By their numbers in this assay, from the lowest: compounds 1 and 3 (each within the scatter of the next); then compound 2.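

In this assay, the group bearing sulfur and a double-bonded nitrogen on this oxygen, in place of cyclohexylcarbamoyl, gives a 17-fold lower number from compound 2 to compound 3 (1.22 log units; beyond the scatter) and so matches the gap seen with compound 1. Vinyl in place of methyl on the saturated chain carbon gives a 1.1-fold higher number from compound 1 to compound 3 (0.03 log units; within the scatter), so both sulfur-bearing groups share the low numbers and compound 2 stands apart. Compound 2 differs from both in sulfur and in its ring, so these compounds leave open which of the two goes with the gap; an ethylcarbamoyl group would separate them, and a longer chain or a phenyl on that nitrogen remains untested here. Nothing measured here gives a reason for the gap.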